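Benzylamino and arylthio analogues on a shared diamino core

The compounds below may be only part of what the source reports. "The series", "measured", "known", "first", "only" and "open" are said of these compounds alone.

Three compounds of the series have been run in a functional assay on LOX IMVI cells (Homo sapiens) for inhibition, read by sulforhodamine B assay, with a stated time of 48 h (on this read-out higher numbers stand for lower toxicity in this test and lower numbers for higher toxicity in this test), so far. Compound 1, `CCOC(=O)[C@H](CCC(=O)O)NC(=O)c1ccc(Sc2nc3cc(N)cc(N)c3nc2-c2ccccc2)cc1`, reaches only the assay limit in this assay and gives < 100000 nM, which is a limit and not a number. Compound 2, `COc1cc(CNc2nc3cc(N)cc(N)c3nc2-c2ccccc2)cc(OC)c1OC`, gives 26300 nM in this assay. Compound 3, `Nc1cc(N)c2nc(-c3ccccc3)c(Sc3ccc(Cl)c(Cl)c3)nc2c1`, gives 72400 nM in this assay. Of the two numbers in hand, compound 2 stands lowest; compound 3 is the nearest, and the gap between them lies beyond the usual scatter. One further value sits at the limit of the assay, as compound 1 shows: the limit of < 100000 nM in this assay, at which 1 of the 3 values shown sits.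

The next compound, compound 4, `COc1ccc(CNc2nc3cc(N)cc(N)c3nc2-c2ccccc2)cc1OC`, has not been measured in this assay. It differs from compound 2 in one place: hydrogen in place of methoxy on an aromatic carbon. The carbon that carries the new hydrogen is ortho to a methoxy group, meta to a large group and meta to a methoxy group. Going by the values given here, no pair of measured compounds in this set differs by a single change of this kind, so nothing in the numbers in hand tells the size of such a step. Among the compounds with values here, since only one methoxy group leaves and the remainder of compound 2 stays as it is, the step is expected to stay within the scatter, with no set direction. Compound 4 is therefore expected to give 30000 nM in this assay, within 12000 nM to 75000 nM.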

Compound 4, concentration lethal to 50% of the cells: < 100000 nM
Compound 4: no number, only a limit; the forecaster's own chance of this, stated with the estimate: 15%; the middle value lies beyond the limit too.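

Compound 4 gives < 100000 nM in this assay, which is a limit and not a number. The step from compound 2 to compound 4 therefore cannot be read. The compounds shown leave open the size and direction of the change when hydrogen takes the place of methoxy on this aromatic carbon.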